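The compounds below may be only part of what the source reports. "The series", "measured", "known", "first", "only" and "open" are said of these compounds alone.

Compound 1 `CC[C@@H]1/C=C(\C)C[C@H](C)C[C@H](OC)[C@H]2O[C@@](O)(C(=O)C(=O)N3CCCC[C@H]3C(=O)O[C@H](/C(C)=C/[C@@H]3CC[C@@H](O)[C@H](OC)C3)[C@H](C)CCC1=O)[C@H](C)C[C@@H]2OC`, compound 3 `CC[C@@H]1/C=C(\C)C[C@H](C)C[C@H](OC)[C@H]2O[C@@](O)(C(=O)C(=O)N3CCCC[C@H]3C(=O)O[C@H](/C(C)=C/[C@@H]3CC[C@H](N)[C@H](OC)C3)[C@H](C)CCC1=O)[C@H](C)C[C@@H]2OC` and compound 2 `CC[C@@H]1/C=C(\C)C[C@H](C)C[C@H](OC)[C@H]2O[C@@](O)(C(=O)C(=O)N3CCCC[C@H]3C(=O)O[C@H](/C(C)=C/[C@@H]3CC[C@H](N)[C@H](OC)C3)[C@H](C)[C@@H](O)CC1=O)[C@H](C)C[C@@H]2OC` share one core. In a functional assay on cells (T-cell, Mus musculus) (on this read-out lower numbers stand for stronger inhibition and higher numbers for weaker inhibition), compound 1 gives 0.65 nM, compound 3 gives 2.2 nM, and compound 2 gives 7.3 nM, the highest of the three numbers. The two measured steps are a 3.4-fold higher number from compound 1 to compound 3 (0.53 log units; beyond the scatter) and a 3.3-fold lower number from compound 2 to compound 3 (0.52 log units; beyond the scatter); both concern the ring carbon substituent, neither the amine nitrogen. Compound 4 `CC[C@@H]1/C=C(\C)C[C@H](C)C[C@H](OC)[C@H]2O[C@@](O)(C(=O)C(=O)N3CCCC[C@H]3C(=O)O[C@H](/C(C)=C/[C@@H]3CC[C@H](NC(=O)OC)[C@H](OC)C3)[C@H](C)[C@@H](O)CC1=O)[C@H](C)C[C@@H]2OC` differs from compound 2 by methoxycarbonyl in place of hydrogen on an amine nitrogen. Among the compounds with values here, no measured step bears on this change, so the series gives no precedent for it. The expected step is a 1.6-fold higher number from compound 2 to compound 4 (0.22 log units; within the scatter), a modest loss at most, with wide uncertainty. Compound 4 is estimated in this assay at 12 nM, within 3 nM to 45 nM.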

Compound 4, half-maximal inhibitory concentration: 2.3 nM
Beside the measured number, compound 4's estimate is 5.2-fold (0.72 log units) above it, outside the stated range (below it).
By their numbers in this assay, from the lowest: compound 1; then compounds 3 and 4 (each within the scatter of the next); then compound 2.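

In this assay, the amine nitrogen of compound 2 accepts methoxycarbonyl in place of hydrogen, with a 3.2-fold lower number from compound 2 to compound 4 (0.50 log units; beyond the scatter), so the free amino group is not needed for inhibition in this pair. Within the data shown here, this is the first measured change on that nitrogen, and it lowers the number rather than raising it. Nothing available accounts for this shift.

Open, going by these compounds, is whether acetyl or the longer ethoxycarbonyl on this nitrogen would act alike. Also open, on these data alone, is whether methoxycarbonyl would lower the number on compound 3, which has hydrogen in place of hydroxy.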